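Adding a nitro group to a level series

A few compounds are considered here, and "the series" means these few. Any claim that something is new, unique, unknown or untested is made for them only; others in the source may bear on it.

In a functional assay on A549 cells (Homo sapiens) for antiproliferative activity, read by XTT assay, with a stated time of 72 h (on this read-out lower numbers stand for stronger inhibition and higher numbers for weaker inhibition), compound 1 `COc1ccc(-c2cc3ccccc3nc2/C=C/C(=O)c2ccccc2)cc1` gives 7410 nM. Compound 2 `COc1ccc(-c2cc3ccccc3nc2/C=C/C(=O)c2ccc(F)cc2)cc1` gives 8320 nM, and compound 3 `COc1ccc(-c2cc3ccccc3nc2/C=C/C(=O)c2ccc(OC)cc2OC)cc1` gives 7990 nM. These three values all lie within the scatter of one another, so compound 1 stands level with the other two and no ranking can be drawn.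

Compound 4 `COc1ccc(-c2cc3ccccc3nc2/C=C/C(=O)c2ccc([N+](=O)[O-])cc2)cc1` has not yet been measured. It keeps the core of compound 1 and places nitro in place of hydrogen on an aromatic carbon, turning phenyl into 4-nitrophenyl: nitro in place of hydrogen on an aromatic carbon.

Among the measured compounds shown here, two measured steps bear on this change. Fluoro in place of hydrogen gave a 1.1-fold higher number from compound 1 to compound 2 (0.05 log units; within the scatter), and 2,4-dimethoxyphenyl in place of phenyl gave a 1.1-fold higher number from compound 1 to compound 3 (0.03 log units; within the scatter). For the measured compounds named here, neither step leaves the scatter, so none beyond it is expected in this assay, in either direction, although no nitro compound has been measured yet.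

The estimated change is a 1.1-fold higher number from compound 1 to compound 4 (0.02 log units; within the scatter). Compound 4 is expected at 7800 nM, with an estimated range of 3500 nM to 16000 nM.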

Compound 4, half-maximal inhibitory concentration: 6310 nM
The estimate for compound 4 lay 1.2-fold (0.09 log units) above the measured number; measured number inside the range.
By their numbers in this assay, from the lowest: compounds 4, 1, 3 and 2 (each within the scatter of the next).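

In this assay, placing a nitro group on this ring, para to a large group, still leaves the number within the scatter, with a 1.2-fold lower number from compound 1 to compound 4 (0.07 log units; within the scatter). The comparisons with the other two substituted compounds also stay within the scatter, with a 1.3-fold lower number from compound 3 to compound 4 (0.10 log units; within the scatter) and a 1.3-fold lower number from compound 2 to compound 4 (0.12 log units; within the scatter), so 4-nitrophenyl, which carries three heavy atoms in its nitro group, joins phenyl, 4-fluorophenyl and 2,4-dimethoxyphenyl in a level set. The data shown offer no explanation for this level picture.

On these data alone, it remains open whether any group at this place can move the number beyond the scatter, as an amine or a carboxylic acid might. The compounds shown also leave open whether this level picture would hold if the methoxy group on the other side of the shared core gave way to a hydroxyl group.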